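A few compounds are considered here, and "the series" means these few. Any claim that something is new, unique, unknown or untested is made for them only; others in the source may bear on it.

Compound 1 `C/C(=N\NC(=O)Nc1nc2ccc(CN(C)C)cc2s1)c1cnccn1` and compound 2 `CCN(CC)Cc1ccc2nc(NC(=O)N/N=C(\C)c3cnccn3)sc2c1` are built on one shared core, while compound 3 `CN(C)Cc1ccc(NC(=O)NN=C(c2ccccc2)c2ccccc2)cc1` is built on another; the difference between the two cores is not broken down here. In a functional assay on U-937 cells (Homo sapiens) for antiproliferative activity, read by CCK-8 assay, with a stated time of 24 h (a higher number here means a weaker inhibitor, a lower number a stronger inhibitor), compound 1 gives only a limit, > 40000 nM. Compound 2 also gives only a limit in this assay, > 40000 nM. The change that separates these two is diethylamino in place of dimethylamino on a saturated chain carbon bound to an aromatic carbon, and the step that the two limits leave unreadable from compound 1 to compound 2 cannot be read off, because both values rest at the limit of > 40000 nM in this assay, at which 2 of the 3 values shown sit. Compound 3 too gives only a limit in this assay, > 25000 nM. Compound 4 `CCN(CC)Cc1ccc(NC(=O)NN=C(c2ccccc2)c2ccccc2)cc1` carries the same change, (diethylamino in place of dimethylamino on a saturated chain carbon bound to an aromatic carbon), at the same place. Among the compounds with values here, the step that the limit leaves unreadable from compound 3 to compound 4 is expected to be essentially flat, since the one measured instance of this change showed no readable movement at the limit of > 40000 nM in this assay, at which 2 of the 3 values shown sit, and compound 3 itself already rests at the limit of > 25000 nM in this assay, at which 1 of the 3 values shown sits. Compound 4 is therefore expected to come out near 40000 nM, most likely again only as a limit, with a plausible range from 20000 nM to 120000 nM.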

Compound 4, half-maximal inhibitory concentration: > 25000 nM
Compound 4: only a limit was reported; the forecaster's own chance of this, stated with the estimate: 90%; the middle value does not contradict the limit.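

No step can be read from compound 3 to compound 4, because both compounds rest at a limit rather than a number: the limit of > 25000 nM in this assay, at which 2 of the 4 values shown sit.

The compounds shown leave open whether diethylamino in place of dimethylamino changes the result in this assay on either core, and how strong any of the four compounds actually is.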